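Methylation of the phenol across two pyrazole chalcone cores

This account rests on a few compounds, and the source may have more. Where it says the series, first, only, none or still open, it means among the compounds named here.

Compounds measured so far:
compound 1 `O=C(/C=C\Nc1ccc(O)cc1)c1cn(-c2ccccc2)nc1-c1ccccc1`: 3600 nM
compound 2 `COc1ccc(N/C=C\C(=O)c2cn(-c3ccccc3)nc2-c2ccccc2)cc1`: 6400 nM
compound 3 `COc1ccc(-c2nn(-c3ccccc3)cc2C(=O)/C=C\Nc2ccc(O)cc2)cc1`: 1980 nM

In a functional assay on PC-3 cells (Homo sapiens) for antiproliferative activity, read by MTT assay, with a stated time of 48 h (on this read-out higher numbers stand for weaker inhibition and lower numbers for stronger inhibition), compound 1 gives 3600 nM. Compound 2 differs from compound 1 by methyl in place of hydrogen on an oxygen on an aromatic ring, and this gave a 1.8-fold higher number from compound 1 to compound 2 (0.25 log units; within the scatter). Compound 3 differs from compound 1 by methoxy in place of hydrogen on an aromatic carbon, and this gave a 1.8-fold lower number from compound 1 to compound 3 (0.26 log units; within the scatter). Compound 4 `COc1ccc(N/C=C\C(=O)c2cn(-c3ccccc3)nc2-c2ccc(OC)cc2)cc1` has not been measured. It differs from compound 3 by methyl in place of hydrogen on an oxygen on an aromatic ring, the same change as from compound 1 to compound 2, made on the core of compound 3 instead of the core of compound 1. Since that change gave a 1.8-fold higher number from compound 1 to compound 2 (0.25 log units; within the scatter), the step from compound 3 to compound 4 is expected to be of like size, a 1.8-fold higher number from compound 3 to compound 4 (0.25 log units; within the scatter), resting on a single earlier pair. Compound 4 is therefore expected to give 3500 nM in this assay, likely between 1500 nM and 8000 nM.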

Compound 4, half-maximal inhibitory concentration: 13400 nM
Compound 4: middle estimate off by 3.8-fold (0.58 log units), on the low side; measured number above the stated range.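

On the core of compound 3, the change from 4-hydroxyphenyl to 4-methoxyphenyl gave a 6.8-fold higher number from compound 3 to compound 4 (0.83 log units; beyond the scatter), so in this assay it did not carry over at the size seen on the core of compound 1: the same change on two cores in this assay, a 1.8-fold higher number (0.25 log units; within the scatter) from compound 1 to compound 2 and a 6.8-fold higher number (0.83 log units; beyond the scatter) from compound 3 to compound 4, 3.8-fold (0.58 log units) apart, beyond the scatter of two such steps

Read the other way, adding methoxy on an aromatic carbon gave a 2.1-fold higher number from compound 2 to compound 4 (0.32 log units; beyond the scatter), which also fails to match its earlier counterpart: the same change on two cores in this assay, a 1.8-fold lower number (0.26 log units; within the scatter) from compound 1 to compound 3 and a 2.1-fold higher number (0.32 log units; beyond the scatter) from compound 2 to compound 4, 3.8-fold (0.58 log units) apart, beyond the scatter of two such steps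

Both gaps rest on the same four compounds, so they record one departure from additivity rather than two, and they do not show why the steps differ or how either change behaves on any other core.

The compounds shown leave open whether an ethyl or a longer chain on the oxygen on the aromatic ring would follow the methyl. They also leave open how an amine in place of the hydroxy would behave on these two cores.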